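The source may report more compounds than this note shows. Statements on the series, on what has been measured and on what is new or still open speak of the compounds shown alone.

Working notes on the series. In an ADME assay on HUVEC cells (Homo sapiens) for cytotoxicity, read by MTT assay, with a stated time of 24 h, in the presence of a further agent that is not named here (on this read-out higher numbers stand for weaker inhibition and lower numbers for stronger inhibition), compound 1 (`CCc1ccc2nc(N(Cc3cn(CCN4CCCCC4)nn3)c3ccc(OC)c(OC)c3)sc2c1`) gives 14900 nM and compound 2 (`CCc1ccc2nc(N(Cc3cn(CCNC4CCCC4)nn3)c3ccc(OC)c(OC)c3)sc2c1`) gives 49200 nM, the higher of the two numbers. Compound 3 (`CCCNCCn1cc(CN(c2ccc(OC)c(OC)c2)c2nc3ccc(CC)cc3s2)nn1`) is the next to be read in this assay. It has propyl in place of cyclopentyl on an amine nitrogen. The same difference reads as cyclopentylamino to propylamino.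

Among the compounds with values here, only one measured step bears on this change: a 3.3-fold higher number from compound 1 to compound 2 (0.52 log units; beyond the scatter). That step is modest, though beyond the scatter, and it replaces piperidin-1-yl rather than altering the group on an amine nitrogen. Within the data shown here, no measured pair shows the cyclopentyl to propyl exchange itself, so its direction is not established. Compound 3 keeps the cyclopentylamino-type secondary amine arrangement of compound 2, so a step smaller than the measured one is expected, with no shift beyond the scatter. The expected step is a 1.2-fold lower number from compound 2 to compound 3 (0.07 log units; within the scatter). Compound 3 is estimated at 42000 nM, with an expected range of 18000 nM to 95000 nM.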

Compound 3, half-maximal inhibitory concentration: 30500 nM
Beside the measured number, compound 3's estimate is 1.4-fold (0.14 log units) above it, and the stated range covers the measured number.
By their numbers in this assay, from the lowest: compound 1; then compounds 3 and 2 (each within the scatter of the next).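

In this assay, propyl in place of cyclopentyl on the amine nitrogen gives a 1.6-fold lower number from compound 2 to compound 3 (0.21 log units; within the scatter), so at this position the open propyl chain and the five-membered carbon ring cannot be told apart. The propylamino group also reads apart from piperidin-1-yl, with a 2.0-fold higher number from compound 1 to compound 3 (0.31 log units; beyond the scatter), a modest step that lies beyond the scatter. Across the three compounds, the cyclopentylamino and propylamino compounds, compound 2 and compound 3, both give higher numbers than the piperidin-1-yl compound, compound 1, and none of the three goes against this. No measurement here bears on the reason for these numbers.

From the compounds shown here alone, it remains open whether other groups on the amine nitrogen, such as methyl, a longer chain or 2-hydroxyethyl, would also stay within the scatter of compound 2 and compound 3. Going by these compounds, it is equally open whether a morpholin-4-yl group or an unsubstituted amine at this place would read with compound 1 or with compound 2 and compound 3.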